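Adding a Phenyl Ring Directly to the Core

A few compounds are considered here, and "the series" means these few. Any claim that something is new, unique, unknown or untested is made for them only; others in the source may bear on it.

Compound 1 `CCc1nnc2sc(-c3cccc(F)c3)nn12` is the starting point. In an assay for inhibition of histone-lysine N-methyltransferase, H3 lysine-79 specific (Homo sapiens), with stated times of 15 min and 120 min, tested at 50 uM (on this read-out lower numbers stand for less inhibition and higher numbers for more inhibition at the one concentration tested (going by the name of the read-out)), compound 1 gives 13%, the lowest of the three numbers available. Two related compounds carry a larger group on the saturated chain carbon bound to the core. Compound 2 `Fc1cccc(-c2nn3c(CSc4ccccc4)nnc3s2)c1` gives 21%, and compound 3 `Fc1cccc(-c2nn3c(Cc4ccccc4F)nnc3s2)c1` gives 25%. The step of a number 8 percentage points higher from compound 1 to compound 2 (within the scatter) stays within the scatter, while the step of a number 12 percentage points higher from compound 1 to compound 3 (beyond the scatter) reaches beyond it, and the step of a number 4 percentage points higher from compound 2 to compound 3 (within the scatter) is again within the scatter.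

Compound 4 `Fc1cccc(-c2nn3c(-c4ccccc4)nnc3s2)c1` differs from compound 1 as follows: phenyl in place of ethyl on an aromatic carbon. Among the compounds with values here, this change puts an aromatic ring straight onto the core, rather than onto a saturated chain carbon, so no measured step matches it exactly. The two steps that add an aromatic ring, from compound 1, both moved the numbers upward by small amounts. A similar small rise, or none beyond the scatter, is therefore expected for compound 4, estimated as a number 7 percentage points higher from compound 1 to compound 4 (within the scatter). Compound 4 is thus expected to give 20% in this assay, with a likely range from 8% to 33%.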

Compound 4, a percentage reported as inhibition, at one concentration (the size of the read-out at that concentration, not a potency): 15%
Compound 4: middle estimate off by 5 percentage points, on the high side, and the stated range covers the measured number.
By their numbers in this assay, from the lowest: compounds 1, 4, 2 and 3 (each within the scatter of the next, the first and the last beyond it).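

In this assay, replacing ethyl with phenyl on this aromatic carbon gives a number 2 percentage points higher from compound 1 to compound 4 (within the scatter), so the larger group, with its aromatic ring attached straight to the core, does not separate the two compounds. Within the data shown here, an aromatic ring at this place is therefore not enough on its own to produce a step beyond the scatter; the one such step from compound 1, a number 12 percentage points higher from compound 1 to compound 3 (beyond the scatter), comes with a ring carried on a saturated chain carbon. Nothing measured here accounts for this result.

Still open, going by these compounds, is whether an amine, a carboxylic acid or a longer chain on this same aromatic carbon would give a clearer step. It is also unknown whether 2-fluorophenyl attached directly to the core would behave like phenyl.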